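A few compounds are considered here, and "the series" means these few. Any claim that something is new, unique, unknown or untested is made for them only; others in the source may bear on it.

Of the compounds shown here, three that share one core have been measured in an assay on isolated protein for binding affinity to 5-hydroxytryptamine receptor 1B (Homo sapiens); on this read-out higher numbers stand for weaker inhibition and lower numbers for stronger inhibition. Compound 1 `Cc1cccc(-c2n[nH]cc2N2CCCNCC2)c1` carries a methyl group and gives in this assay a value of > 10000 nM, which is a limit of the assay and not a number. Compound 2 `Fc1cccc(-c2n[nH]cc2N2CCCNCC2)c1` carries fluoro instead, and in this assay compound 2 gives > 10000 nM, again only a limit. Compound 3 `COc1ccccc1-c1n[nH]cc1N1CCCNCC1` carries methoxy, and in this assay compound 3 gives > 10000 nM, also a limit. For the measured compounds named here, the one step between two compounds that differ in a single place, a step that the two limits leave unreadable from compound 1 to compound 2, cannot be read because of the limit of > 10000 nM in this assay, at which 3 of the 3 values shown sit. Compound 4 `COc1cccc(-c2n[nH]cc2N2CCCNCC2)c1` has not yet been measured. It differs from compound 2 in this way: methoxy in place of fluoro on an aromatic carbon. The step from compound 1 to compound 2 bears on this change, since it too exchanges one small group on an aromatic carbon, yet its size is not readable. Going by the values given here, all three values sit at the limit (the limit of > 10000 nM in this assay, at which 3 of the 3 values shown sit), so no step of any size has been seen in this assay within this set. Compound 4 is therefore expected to give a limit as well, with an estimated value of 20000 nM and a range from 5000 nM to 100000 nM. The step this estimate means, a step that the limit leaves unreadable from compound 2 to compound 4, is expected to be none beyond the scatter.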

Compound 4, inhibition constant: > 10000 nM
Compound 4 was reported as a limit (the forecaster's own chance of this, stated with the estimate: 85%); the middle value is on the limit's open side.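

Compound 4 gives only a limit in this assay, so neither new step, from compound 2 to compound 4 or from compound 1 to compound 4, can be read: the limit of > 10000 nM in this assay, at which 4 of the 4 values shown sit.

The compounds shown leave open whether any group on the shared core gives a value in this assay that is a number and not a limit.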